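This account rests on a few compounds, and the source may have more. Where it says the series, first, only, none or still open, it means among the compounds named here.

Measured so far:
compound 1, `N#Cc1cnc(NCc2cnccc2C(F)(F)F)cc1N[C@H]1CC[C@H](O)CC1`: 350 nM
compound 2, `N#Cc1cnc(NCc2ccccc2C(F)(F)F)cc1N[C@H]1C[C@H](C(N)=O)C1`: 5000 nM

Both numbers come from an assay on isolated protein for inhibition of protein kinase C theta type (Homo sapiens), read by TR-FRET, with a stated time of 2 h; on this read-out higher numbers stand for weaker inhibition and lower numbers for stronger inhibition. On the numbers shown, compound 1 holds the lower value; compound 2 sits far higher, a gap beyond the usual scatter. For the measured compounds named here, the two compounds differ in more than one place, so the gap cannot be read as a single step, and no single-change step between measured compounds exists in this set.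

Compound 3, `CNC(=O)[C@H]1CC[C@@H](Nc2cc(NCc3cnccc3C(F)(F)F)ncc2C#N)CC1`, has not yet been measured. Against compound 1 the change is 4-(methylcarbamoyl)cyclohexyl in place of 4-hydroxycyclohexyl on a nitrogen on an aromatic ring. Nothing measured isolates this change, so the expectation rests on compound 1 alone. The expected step in this assay is small, if anything toward weaker inhibition, and may well lie within the scatter. Compound 3 is estimated at 500 nM, with a range from 150 nM to 2000 nM. The step of a 1.4-fold higher number from compound 1 to compound 3 (0.15 log units; within the scatter) that this estimate implies is modest.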

Compound 3, half-maximal inhibitory concentration: 27 nM
Estimate against measurement, compound 3: 19-fold (1.27 log units) above; the whole stated range lies above it.
By their numbers in this assay, from the lowest: compound 3; then compound 1; then compound 2.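

At the place on a nitrogen on an aromatic ring, the substituent strongly affects the read-out: in this assay the change to 4-(methylcarbamoyl)cyclohexyl from 4-hydroxycyclohexyl gives a 13-fold lower number from compound 1 to compound 3 (1.11 log units; beyond the scatter) with the rest of the structure unchanged. For the compounds shown here, this is the only single-change step, and it shows that the entering group, though larger by heavy atom count, is accepted here and lowers the number well beyond the scatter. Nothing measured here accounts for this step.

The compounds shown leave open which part of the 4-(methylcarbamoyl)cyclohexyl group carries the step, and a primary carboxamide, a carboxylic acid or an amine on the same cyclohexyl ring would help separate those parts. From the compounds shown here alone, whether the step holds on the core of compound 2 also remains open.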